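A few compounds are considered here, and "the series" means these few. Any claim that something is new, unique, unknown or untested is made for them only; others in the source may bear on it.

Compound 1 `COc1ccc(NC2=CC(=O)c3c(nc4n3[C@H]3OC[C@@H](O)[C@H]3OC4)C2=O)cc1` — 3410 nM
Compound 2 `CCOc1ccccc1NC1=CC(=O)c2c(nc3n2[C@H]2OC[C@@H](O)[C@H]2OC3)C1=O` — 4320 nM
Compound 3 `Cc1ccc(NC2=CC(=O)c3c(nc4n3[C@H]3OC[C@@H](O)[C@H]3OC4)C2=O)cc1` — > 4000 nM

The three measured compounds share one core and differ only in the aryl group on the amine nitrogen. In a functional assay on ECa-109 cells for inhibition, with ECa-109 cell line (Homo sapiens) as the target, read by sulforhodamine B assay (a higher number here means a weaker inhibitor, a lower number a stronger inhibitor), compound 1 gives 3410 nM. In this assay compound 2 gives 4320 nM, a step of a 1.3-fold higher number from compound 1 to compound 2 (0.10 log units; within the scatter). Within the data shown here, for compound 3 this assay reports only a limit, > 4000 nM, and it is the one value sitting at the limit of > 4000 nM in this assay, at which 1 of the 3 values shown sits. From compound 1 the step is an at least 1.1-fold higher number from compound 1 to compound 3 (0.06 log units; that floor lies within the scatter), and the other step is a step that the limit leaves unreadable from compound 2 to compound 3. Compound 3 therefore stands as a limit only, with no number of its own.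

Compound 4 `O=C1C(Nc2ccccc2F)=CC(=O)c2c1nc1n2[C@H]2OC[C@@H](O)[C@H]2OC1` has not been measured. It differs from compound 3 in one place: 2-fluorophenyl in place of 4-methylphenyl on an amine nitrogen. Among the measured compounds shown here, the steps that bear on this swap are those among compounds 1, 2 and 3, each an exchange of the aryl group on the amine nitrogen, and none of them is readable as a move beyond the scatter. The step expected is therefore a step that the limit leaves unreadable from compound 3 to compound 4, nothing beyond the scatter. Compound 4 is estimated at 4500 nM in this assay, with a range from 2500 nM to 9000 nM, and a fair chance that only a limit is reported once more.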

Compound 4, half-maximal inhibitory concentration: 2660 nM
The estimate for compound 4 lay 1.7-fold (0.23 log units) above the measured number, and the stated range covers the measured number.
By their numbers in this assay, from the lowest: compounds 4, 1 and 2 (each within the scatter of the next).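

Compared with the alkoxy-bearing aryl groups in this assay, 2-fluorophenyl on the amine nitrogen gives a 1.3-fold lower number from compound 1 to compound 4 (0.11 log units; within the scatter) and a 1.6-fold lower number from compound 2 to compound 4 (0.21 log units; within the scatter). Among these compounds, a fluoro group on the aryl ring, a kind of substituent the earlier compounds did not carry, therefore leaves the number within the scatter of those with methoxy and ethoxy. Against the 4-methylphenyl group there is only a floor, an at least 1.5-fold lower number from compound 3 to compound 4 (0.17 log units; that floor lies within the scatter), and compound 3 remains the one compound held by a limit and not a number: the limit of > 4000 nM in this assay, at which 1 of the 4 values shown sits.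

From the compounds shown here alone, whether the true gap between compound 3 and compound 4 lies beyond the scatter stays open. So does whether an amine or a carboxylic acid on the aryl ring, or a longer chain in place of the aryl group on the amine nitrogen, would shift the number beyond the scatter.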